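The source may hold more compounds than are shown below. What is called first, only, known or untested is meant among the compounds shown, and "the series" means these compounds.

Measured in a functional assay on MCF7 cells (Homo sapiens) for inhibition, with a stated time of 72 h; a higher number here means a weaker inhibitor, a lower number a stronger inhibitor:
- compound 1 `NC1CCC(Nc2nc(NCc3ccc(-c4ccco4)cc3)c3ncn(C4CCCC4)c3n2)CC1` - 85 nM
- compound 2 `NC1CCC(Nc2nc(NCc3ccc(-c4ccccc4)nc3)c3ncn(C4CCCC4)c3n2)CC1` - 483 nM

Compound 2 holds the higher of the two numbers, at 483 nM. Compound 3 `Nc1ccccc1CNc1nc(NC2CCC(N)CC2)nc2c1ncn2C1CCCC1` differs from it by 2-aminophenyl in place of 6-phenylpyridin-3-yl on a saturated chain carbon bound to a nitrogen on an aromatic ring, with 2-aminophenyl in place of 6-phenylpyridin-3-yl on a saturated chain carbon bound to a nitrogen on an aromatic ring. Going by the values given here, only one measured step bears on this change: a 5.7-fold higher number from compound 1 to compound 2 (0.75 log units; beyond the scatter). It concerns the same place, but it gives no direction for 2-aminophenyl. No step beyond the scatter is therefore expected in this assay, and the range is kept wide. The expected step is a 1.2-fold higher number from compound 2 to compound 3 (0.09 log units; within the scatter). For compound 3 the estimate is 600 nM, with an expected range of 150 nM to 2500 nM.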

Compound 3, half-maximal inhibitory concentration: 2330 nM
Compound 3: middle estimate off by 3.9-fold (0.59 log units), on the low side; low and high end bracket the measured number.
By their numbers in this assay, from the lowest: compound 1; then compound 2; then compound 3.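

In this assay, 2-aminophenyl on this saturated chain carbon gives a 4.8-fold higher number from compound 2 to compound 3 (0.68 log units; beyond the scatter) and a 27-fold higher number from compound 1 to compound 3 (1.44 log units; beyond the scatter), placing it behind both 4-(furan-2-yl)phenyl and 6-phenylpyridin-3-yl. Compared with 6-phenylpyridin-3-yl, this change removes one ring and adds a hydrogen-bond donor together, and the two changes cannot be separated here. No measurement shown accounts for the rise. A plain phenyl group would help separate the loss of the second ring from the entry of the amine. As far as these compounds go, whether a larger group carrying an amine recovers the lower numbers remains open.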